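A few compounds are considered here, and "the series" means these few. Any claim that something is new, unique, unknown or untested is made for them only; others in the source may bear on it.

In a functional assay on the whole organism (strain Sprague-Dawley) for inhibition, with Rattus norvegicus as the target, with a stated time of 10 min (on this read-out higher numbers stand for an effect only at larger amounts of compound and lower numbers for an effect already at smaller amounts), compound 1 `O=C(O)c1cnc(-c2ccccc2Cl)[nH]c1=O` gives 5 mg/kg. Compound 2 `O=C(O)c1cnc(-c2ccccc2[N+](=O)[O-])[nH]c1=O` gives > 50 mg/kg, which is a limit of the assay and not a number. Compound 3 `CCOc1ccccc1-c1ncc(C(=O)O)c(=O)[nH]1` differs from it as follows: ethoxy in place of nitro on an aromatic carbon. Among the measured compounds shown here, one measured step bears on this place: an at least 10-fold higher number from compound 1 to compound 2 (1.00 log units; beyond the scatter), nitro in place of chloro. For the measured compounds named here, no measured step carries ethoxy, so the size is uncertain. Loss of the nitro is expected to bring the number down, toward compound 1 at 5 mg/kg. The expected change is an at least 6.2-fold lower number from compound 2 to compound 3 (0.79 log units; beyond the scatter). For compound 3 the estimate is 8 mg/kg, with an expected range of 1.5 mg/kg to 40 mg/kg.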

Compound 3, dose for 50% inhibition: 0.5 mg/kg
Compound 3: the middle estimate sits 16-fold (1.20 log units) above what was measured; measured number outside the range, below it.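

Ethoxy at this position goes beyond chloro, with a 10-fold lower number from compound 1 to compound 3 (1.00 log units; beyond the scatter), so the chloro of compound 1 does not mark the best value seen at this place. Ethoxy and nitro both count 3 heavy atoms, yet the change reads as an at least 100-fold lower number from compound 2 to compound 3 (2.00 log units; beyond the scatter), so heavy-atom count alone does not separate the two groups. The size of that step rests on compound 2, whose value is a limit of the assay and not a number: the limit of > 50 mg/kg in this assay, at which 1 of the 3 values shown sits.

On these data alone, whether methoxy, a longer alkoxy chain or an amine at this position would follow ethoxy remains open. With ethoxy the only such group shown, the compounds give no reason for its gain.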